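Shrinking the 1,3-benzothiazol-2-yl end of compound 3

This account rests on a few compounds, and the source may have more. Where it says the series, first, only, none or still open, it means among the compounds named here.

- Compound 1 `COc1ccc(CN(C(=O)Cn2cc(COc3cc(=O)oc4ccccc34)nn2)c2cc(OC)c(OC)c(OC)c2)cc1` gives 5140 nM
- Compound 2 `COc1ccc(CN(C(=O)Cn2cc(COc3ccc4ccc(=O)oc4c3)nn2)c2cc(OC)c(OC)c(OC)c2)cc1` gives 860 nM
- Compound 3 `COc1ccc(CN(C(=O)Cn2cc(CSc3nc4ccccc4s3)nn2)c2cc(OC)c(OC)c(OC)c2)cc1` gives 28500 nM

In a functional assay on PC-3 cells (Homo sapiens) for antiproliferative activity, read by MTT assay, with a stated time of 48 h (on this read-out lower numbers stand for stronger inhibition and higher numbers for weaker inhibition), compound 3 gives 28500 nM as the highest of the three numbers, which makes it the weakest of this small set. Compound 4 `COc1ccc(CN(C(=O)Cn2cc(CSC3=NCCS3)nn2)c2cc(OC)c(OC)c(OC)c2)cc1` differs from compound 3 on a sulfur, with a group of 5 heavy atoms (3 carbon, 1 nitrogen, 1 sulfur; one five-membered non-aromatic ring with 2 hetero atoms) in place of a group of 9 heavy atoms (7 carbon, 1 nitrogen, 1 sulfur; one five-membered aromatic ring with 2 hetero atoms, one six-membered aromatic ring of carbon only), on a sulfur as the change, so that the 1,3-benzothiazol-2-yl group leaves and a five-membered non-aromatic ring enters.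

Three measured steps exchange the group at this end of the molecule. Of these, a 5.5-fold higher number from compound 1 to compound 3 (0.74 log units; beyond the scatter) is modest, a 33-fold higher number from compound 2 to compound 3 (1.52 log units; beyond the scatter) is large, and a 6.0-fold lower number from compound 1 to compound 2 (0.78 log units; beyond the scatter) is again modest. Among these three compounds, then, this end clearly affects the number. Among the measured compounds shown here, no measured pair, however, removes only the six-membered aromatic ring of carbon only, and that leaves the direction open.

Starting from compound 3 at 28500 nM, a step no larger than the modest ones is expected in this assay, with only a slight lean towards a lower number. The step expected is a 1.4-fold lower number from compound 3 to compound 4 (0.15 log units; within the scatter) in this estimate. The estimate for compound 4 is 20000 nM with an expected range from 6000 nM to 60000 nM overall.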

Compound 4, half-maximal inhibitory concentration: 16000 nM
Estimate against measurement, compound 4: 1.3-fold (0.10 log units) above; measured number inside the range.
By their numbers in this assay, from the lowest: compound 2; then compound 1; then compounds 4 and 3 (each within the scatter of the next).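

In this assay, among the compounds shown here, the step of a 1.8-fold lower number from compound 3 to compound 4 (0.25 log units; within the scatter) isolates what the earlier pairs could not: the 1,3-benzothiazol-2-yl group gives way on the same sulfur to a smaller five-membered non-aromatic ring, and the six-membered aromatic ring of carbon only goes with it, yet the two compounds cannot be told apart. The gap to the two earlier groups that carry oxygen in place of sulfur remains, with a 3.1-fold higher number from compound 1 to compound 4 (0.49 log units; beyond the scatter) and a 19-fold higher number from compound 2 to compound 4 (1.27 log units; beyond the scatter), both beyond the scatter, so this gap does not depend on keeping the benzothiazolyl group. Nothing available explains these results or shows why the numbers fall where they do.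

The compounds shown leave open whether the sulfur itself or the ring group attached to it accounts for that gap, since no pair among them keeps the ring group fixed and exchanges only the linking atom. Also open, from the compounds shown here alone, is how this sulfur would read with no ring at all, carrying for example a plain butyl chain or a dimethylaminoethyl chain.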